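Aryl Sulfonamide Variation on a Triazole-Linked Lactone Scaffold

The compounds below may be only part of what the source reports. "The series", "measured", "known", "first", "only" and "open" are said of these compounds alone.

Measured compounds:
compound 1, `CC(C)(C)c1cn(C[C@H](O)[C@H]2OC(=O)C(OCc3ccccc3)=C2OCc2ccccc2)nn1`, 18300 nM
compound 2, `Cc1ccc(S(=O)(=O)NCc2cn(C[C@H](O)[C@H]3OC(=O)C(OCc4ccccc4)=C3OCc3ccccc3)nn2)cc1`, 14400 nM
compound 3, `O=C1O[C@H]([C@@H](O)Cn2cc(CNS(=O)(=O)c3ccc(Cl)cc3F)nn2)C(OCc2ccccc2)=C1OCc1ccccc1`, 20700 nM

The three compounds share one core and differ only in the group carried on the triazole. In a functional assay on HeLa cells (Homo sapiens) for antiproliferative activity, read by MTT assay, with a stated time of 72 h (a lower number here means a stronger inhibitor, a higher number a weaker inhibitor), compound 1 gives 18300 nM, compound 2 gives 14400 nM and compound 3 gives 20700 nM. Compound 3 shows the highest of the three numbers, but the whole set sits within the scatter of one another: a 1.3-fold lower number from compound 1 to compound 2 (0.10 log units; within the scatter) and a 1.4-fold higher number from compound 2 to compound 3 (0.16 log units; within the scatter).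

Compound 4, `O=C1O[C@H]([C@@H](O)Cn2cc(CNS(=O)(=O)c3ccc(F)cc3)nn2)C(OCc2ccccc2)=C1OCc1ccccc1`, has not yet been measured. It differs from compound 3 at a single place: 4-fluorophenyl in place of 4-chloro-2-fluorophenyl on a sulfonyl sulfur. The step that bears on it is the earlier exchange of one aryl group for another on the sulfonyl sulfur, a 1.4-fold higher number from compound 2 to compound 3 (0.16 log units; within the scatter), which stayed within the scatter. On that basis the expected step of a 1.1-fold lower number from compound 3 to compound 4 (0.04 log units; within the scatter) is none beyond the scatter. Compound 4 is therefore estimated to give 19000 nM in this assay, with a range from 9000 nM to 40000 nM.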

Compound 4, half-maximal inhibitory concentration: 25000 nM
Compound 4: the middle estimate sits 1.3-fold (0.12 log units) below what was measured; the measured number falls inside the stated range.
By their numbers in this assay, from the lowest: compounds 2, 1, 3 and 4 (each within the scatter of the next).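

Taking 4-chloro-2-fluorophenyl to 4-fluorophenyl on the sulfonyl sulfur stays within the scatter in this assay (a 1.2-fold higher number from compound 3 to compound 4 (0.08 log units; within the scatter)), so a third aryl group at this position also gives no step beyond it. Fluoro in place of methyl on an aromatic carbon likewise stays within the scatter (a 1.7-fold higher number from compound 2 to compound 4 (0.24 log units; within the scatter)), as does the exchange of tert-butyl for the whole sulfonamide side chain (a 1.4-fold higher number from compound 1 to compound 4 (0.14 log units; within the scatter)), so all three sulfonamides remain within the scatter of the tert-butyl compound 1. Nothing available explains these small steps.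

The aryl groups shown carry only methyl, fluoro and chloro, so it remains open whether an amine or a carboxylic acid on that ring would move the number beyond the scatter. Also open, as far as these compounds go, is what a longer chain on the triazole would do.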